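This account rests on a few compounds, and the source may have more. Where it says the series, first, only, none or still open, it means among the compounds named here.

Working notes on the series.

Compound 1 is `CCOC(=O)c1nn(-c2ccc(C(C)(C)C)cc2)c(=O)c2c(N)scc12` and compound 2 is `CCOC(=O)c1nn(-c2ccc([N+](=O)[O-])cc2)c(=O)c2c(N)scc12`; the two share the core and differ only in the group on the aromatic carbon. In an assay on CHO-K1 cells for displacement of a labelled ligand from adenosine receptor A1 (Homo sapiens), tested at 50 uM (a lower number here means less inhibition, a higher number more inhibition at the concentration tested (going by the name of the read-out)), compound 1 gives 23%, and compound 2 gives 73.4%. Going by the values given here, the step of a number 50.4 percentage points higher from compound 1 to compound 2 (beyond the scatter) is the one measured step, and it places compound 2 highest of the two numbers, beyond the scatter from compound 1.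

Compound 3 is `CCOC(=O)c1nn(-c2ccc(OS(=O)(=O)C(F)(F)F)cc2)c(=O)c2c(N)scc12`, where (((trifluoromethyl)sulfonyl)oxy in place of nitro on an aromatic carbon). Among the compounds with values here, the step from compound 1 to compound 2 touches the same aromatic carbon, but it shows only that the nitro group lies well above tert-butyl; no measured compound carries ((trifluoromethyl)sulfonyl)oxy, so it is not known where that group falls between the two. The expected step of a number 28.4 percentage points lower from compound 2 to compound 3 (beyond the scatter) in this assay is therefore downward, with wide uncertainty. Compound 3 is estimated at 45%, in the range 15% to 75%.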

Compound 3, a percentage reported as inhibition, at one concentration (the size of the read-out at that concentration, not a potency): 21.5%
Beside the measured number, compound 3's estimate is 23.5 percentage points above it, and the stated range covers the measured number.
By their numbers in this assay, from the lowest: compounds 3 and 1 (each within the scatter of the next); then compound 2.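

In this assay the change from nitro to ((trifluoromethyl)sulfonyl)oxy on this aromatic carbon gives a number 51.9 percentage points lower from compound 2 to compound 3 (beyond the scatter) and so removes the whole lead that compound 2 held, while the comparison with tert-butyl gives a number 1.5 percentage points lower from compound 1 to compound 3 (within the scatter) and leaves those two groups level. Of the three groups at this position, only nitro stands apart, so the compounds read as one high number against two that cannot be separated, not as a graded order. Nothing available explains why nitro differs from the other two groups.

The compounds shown leave open whether the high number belongs to nitro alone or extends to other groups on this carbon, such as a nitrile, an amine or a carboxylic acid. From the compounds shown here alone, it is also open whether a carboxylic acid in place of the ethyl ester on the shared core would move the number with nitro kept in place.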